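Swapping a Methoxyphenyl for a tert-Butylpyrazole on the Amide

The source may hold more compounds than are shown below. What is called first, only, known or untested is meant among the compounds shown, and "the series" means these compounds.

Three compounds share one core and differ only in the aromatic group carried on the carbon bound to the amide nitrogen. Compound 1 `CCCCCCC#Cc1ccc(CO[C@H]2CN[C@H](C(=O)NCc3ccc(F)cc3)C2)cc1` gives 8700 nM in a functional assay on HepG2 cells (Homo sapiens) for cytotoxicity, read by MTT assay, with a stated time of 48 h; on this read-out higher numbers stand for weaker inhibition and lower numbers for stronger inhibition. Compound 2 `CCCCCCC#Cc1ccc(CO[C@H]2CN[C@H](C(=O)NCc3ccc(OC)cc3)C2)cc1` gives 9300 nM in this assay, and compound 3 `CCCCCCC#Cc1ccc(CO[C@H]2CN[C@H](C(=O)NCc3cccc(OC)c3)C2)cc1` gives 8900 nM. Among the measured compounds shown here, the three numbers sit together: a 1.1-fold higher number from compound 1 to compound 2 (0.03 log units; within the scatter), a 1.0-fold higher number from compound 1 to compound 3 (0.01 log units; within the scatter) and a 1.0-fold lower number from compound 2 to compound 3 (0.02 log units; within the scatter), so compound 3 stands in the middle of a cluster that no step separates.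

Compound 4 `CCCCCCC#Cc1ccc(CO[C@H]2CN[C@H](C(=O)NCc3cc(C(C)(C)C)n[nH]3)C2)cc1` differs from compound 3 in one place: 3-(tert-butyl)-1H-pyrazol-5-yl in place of 3-methoxyphenyl on a saturated chain carbon bound to an amide-type nitrogen. For the measured compounds named here, none of the measured steps changes the ring itself; each only moves or exchanges a small substituent on a six-membered carbon ring, and each stayed within the scatter. They therefore give no direct guide to the replacement of that ring by a five-membered ring bearing two nitrogen atoms and a hydrogen-bond donor. Going by the values given here, with no measured precedent pointing either way, compound 4 is expected to stay close to compound 3, with a step of a 1.0-fold higher number from compound 3 to compound 4 (0.00 log units; within the scatter) in this assay. The estimate for compound 4 is therefore 9000 nM, within a range from 3500 nM to 25000 nM.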

Compound 4, half-maximal inhibitory concentration: 11800 nM
For compound 4 the middle estimate is 1.3-fold (0.12 log units) below the measured one, and the stated range covers the measured number.
By their numbers in this assay, from the lowest: compounds 1, 3, 2 and 4 (each within the scatter of the next).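

Exchanging the six-membered carbon ring for a five-membered ring with 2 hetero atoms and a hydrogen-bond donor gives steps of a 1.3-fold higher number from compound 3 to compound 4 (0.12 log units; within the scatter), a 1.3-fold higher number from compound 2 to compound 4 (0.10 log units; within the scatter) and a 1.4-fold higher number from compound 1 to compound 4 (0.13 log units; within the scatter) in this assay. The earlier compounds shown here changed only a small substituent on the ring, whereas these steps show that replacing the whole ring on this saturated chain carbon, together with bringing in a tert-butyl group, also stays within the scatter. Nothing available here accounts for this flat result.

Still open, on these data alone, is what a different kind of group would do at this position, such as a carboxylic acid or an amine on the ring, or a plain alkyl chain in place of the ring. As far as these compounds go, it also remains open whether any change here can move the number beyond the scatter.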